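The source may hold more compounds than are shown below. What is called first, only, known or untested is meant among the compounds shown, and "the series" means these compounds.

Measured so far:
- compound 1, `Nc1nc(O)c2c(n1)n(C1OC(CO)[C@@H](O)[C@H]1O)c(=O)n2CC(O)CO`: 136%
- compound 2, `N#Cc1cccc(Cn2c(=O)n(C3OC(CO)[C@@H](O)[C@H]3O)c3nc(N)nc(O)c32)c1`: 16%

In a functional assay on the whole organism (B cells) with Mus musculus as the target (on this read-out lower numbers stand for smaller maximal responses and higher numbers for larger maximal responses), compound 1 gives 136%, and compound 2 gives 16%. Going by the values given here, compound 2 therefore stands at the lower of the two numbers known here, and the single measured step, a number 120 percentage points lower from compound 1 to compound 2 (beyond the scatter), is the only guide available.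

Compound 3, `NC(=O)Cn1c(=O)n(C2OC(CO)[C@@H](O)[C@H]2O)c2nc(N)nc(O)c21`, has not yet been measured. It differs from compound 2 as follows: carbamoyl in place of 3-cyanophenyl on a saturated chain carbon bound to an aromatic nitrogen. So the 3-cyanophenyl that arrived in the step from compound 1 to compound 2 now leaves again, and a carbamoyl, a group without any ring, takes its place. From the compounds shown here alone, since the arrival of the 3-cyanophenyl went with a large fall in this assay, its departure is expected to go with a rise of comparable direction, though how far the carbamoyl behaves like the 1,2-dihydroxyethyl of compound 1 is unknown. For compound 3 the expected step is a number 84 percentage points higher from compound 2 to compound 3 (beyond the scatter). The estimate for compound 3 in this assay is 100%, with a range from 40% to 150%.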

Compound 3, largest response reached (reported as maximal response), in percent of the reference or control that the assay uses: 32%
Beside the measured number, compound 3's estimate is 68 percentage points above it; measured number outside the range, below it.
By their numbers in this assay, from the lowest: compound 2; then compound 3; then compound 1.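

In this assay, replacing the ring-bearing group with a group without any ring does not restore the response: the change is a number 16 percentage points higher from compound 2 to compound 3 (beyond the scatter), a modest rise, while the comparison with the 1,2-dihydroxyethyl compound gives a number 104 percentage points lower from compound 1 to compound 3 (beyond the scatter), a large fall. The low response at this position is therefore not tied to the 3-cyanophenyl alone, since a carbamoyl on the same saturated chain carbon bound to an aromatic nitrogen also leaves the number far under that of compound 1. Among the three groups seen here, the 1,2-dihydroxyethyl alone gives a large response, and no measurement available here explains why.

The compounds shown leave open whether a single hydroxyl on a shorter chain, as in 2-hydroxyethyl, would keep the large response of compound 1 or fall toward that of compound 3. They also leave open where an amine or a carboxylic acid on the same saturated chain carbon would stand among these three compounds.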